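The compounds below may be only part of what the source reports. "The series", "measured", "known", "first", "only" and "open" are said of these compounds alone.

Working notes on the series around the shared core of compound 1 `COC(=O)c1c[nH]c2ccc(OCc3ccccc3)cc2c1=O`, with compound 2 `COC(=O)c1c[nH]c2ccc(OCCc3ccccc3)cc2c1=O` and compound 3 `COC(=O)c1c[nH]c2ccc(OCCCc3ccccc3)cc2c1=O` differing from it only in the chain that carries the phenyl. In an ADME assay on J774 cells (Mus musculus) for cytotoxicity (on this read-out higher numbers stand for an effect only at larger amounts of compound and lower numbers for an effect already at smaller amounts), compound 1 gives 7590 nM, compound 2 gives 2200 nM and compound 3 gives 17100 nM, the highest number of the three. Next is compound 4 `COC(=O)c1c[nH]c2ccc(OC)cc2c1=O`, which has hydrogen in place of phenethyl on a saturated chain carbon bound to an oxygen on an aromatic ring. The steps at this place are a 3.5-fold lower number from compound 1 to compound 2 (0.54 log units; beyond the scatter), a 7.8-fold higher number from compound 2 to compound 3 (0.89 log units; beyond the scatter) and a 2.3-fold higher number from compound 1 to compound 3 (0.35 log units; beyond the scatter). All are modest and beyond the scatter, but they show no steady trend with chain length, and compound 2 goes against one. Within the data shown here, no measured step removes the whole group, so the direction in this assay stays open, and no large step is expected. The expected change is a 1.4-fold lower number from compound 3 to compound 4 (0.15 log units; within the scatter), a slightly lower number that would stay within the scatter. For compound 4 the estimate is 12000 nM, with an expected range of 4000 nM to 40000 nM.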

Compound 4, half-maximal effective concentration: 6180 nM
Compound 4: middle estimate off by 1.9-fold (0.29 log units), on the high side, within the range that was stated.
By their numbers in this assay, from the lowest: compound 2; then compounds 4 and 1 (each within the scatter of the next); then compound 3.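

Taking the whole chain off the oxygen gives a step in both directions in this assay: with hydrogen in place of phenethyl there is (a 2.8-fold lower number from compound 3 to compound 4 (0.44 log units; beyond the scatter)), and with hydrogen in place of benzyl there is (a 2.8-fold higher number from compound 2 to compound 4 (0.45 log units; beyond the scatter)), while hydrogen in place of phenyl gives only (a 1.2-fold lower number from compound 1 to compound 4 (0.09 log units; within the scatter)). The phenyl-bearing chain is therefore not needed for a number in this range at this position, and among the compounds shown, the phenyl-bearing chains can lie on either side of compound 4 or within the scatter of it, so removing the chain has no single direction. Nothing measured here accounts for these steps.

An amine or a carboxylic acid at the end of the chain, or a chain longer than that of compound 3, could move the number either way. The compounds shown do not tell which.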